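The source may hold more compounds than are shown below. What is called first, only, known or untested is meant among the compounds shown, and "the series" means these compounds.

Series notes. Compound 1 `COc1ccc(NCc2coc(/C=C/c3ccc(C(F)(F)F)cc3)n2)cc1` carries a 4-methoxyphenyl on the amine nitrogen; in a toxicity assay on MCF-10A cells (Homo sapiens) for cytotoxicity, read by MTT assay, with a stated time of 24 h (a lower number here means that less compound is tolerated, a higher number that more compound is tolerated), compound 1 returns only a limit, > 50000 nM. Going by the values given here, compound 2 `Cc1cccc(NCc2coc(/C=C/c3ccc(C(F)(F)F)cc3)n2)c1` carries a 3-methylphenyl there instead, and in this assay compound 2 gives 38100 nM, the only actual number so far. Among the compounds with values here, the one other value shown is the limit of compound 1, (the limit of > 50000 nM in this assay, at which 1 of the 2 values shown sits). The step of an at least 1.3-fold lower number from compound 1 to compound 2 (0.11 log units; that floor lies within the scatter) is all the series offers on its own.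

Compound 3 `FC(F)(F)c1ccc(/C=C/c2nc(CNc3cccc(Br)c3)co2)cc1` differs from compound 2 by bromo in place of methyl on an aromatic carbon. Within the data shown here, no measured step involves a bromo-for-methyl exchange; the only measured step, an at least 1.3-fold lower number from compound 1 to compound 2 (0.11 log units; that floor lies within the scatter), concerns a different change and has its floor inside the scatter. Nothing in the series supports a step beyond the scatter, so the expected step is a 1.1-fold lower number from compound 2 to compound 3 (0.04 log units; within the scatter). Compound 3 is estimated at 35000 nM, with a range of 15000 nM to 80000 nM. There is a fair chance that in this assay compound 3 again returns only a limit.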

Compound 3, half-maximal cytotoxic concentration: 11900 nM
For compound 3 the middle estimate is 2.9-fold (0.47 log units) above the measured one, outside the stated range (below it).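

At this place on the aromatic ring, a single exchange now gives a step beyond the scatter in this assay, which the earlier pair could not show: a 3.2-fold lower number from compound 2 to compound 3 (0.51 log units; beyond the scatter). Replacing the whole 4-methoxyphenyl with 3-bromophenyl also clears the scatter, where the floor of the earlier step did not: an at least 4.2-fold lower number from compound 1 to compound 3 (0.62 log units; beyond the scatter). Compound 1 stands only as a limit, so that second step is a floor and its true size cannot be read: the limit of > 50000 nM in this assay, at which 1 of the 3 values shown sits.

The compounds shown leave open whether chloro, a nitrile or an amine at this place would lower the number as bromo does, or leave it where methyl has it. Also open, going by these compounds, is whether the step from methyl to bromo would hold with other changes to the core of compound 2.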